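Hydrogen for methyl on the cyclobutane of compound 3

This account rests on a few compounds, and the source may have more. Where it says the series, first, only, none or still open, it means among the compounds named here.

Three compounds of the series have numbers in an assay on HEK293 cells for antagonist activity at transient receptor potential cation channel subfamily V member 3 (Homo sapiens), read by FLIPR and calcium flux; a higher number here means a weaker inhibitor, a lower number a stronger inhibitor. Compound 1 `OC(c1ncccn1)C1(c2ccc(OC(F)(F)F)cc2)CCC1` gives 1540 nM in this assay. Compound 2 `O[C@H](c1ccccn1)[C@]1(c2ccc(C(F)(F)F)cc2)C[C@@H](O)C1` gives 1870 nM. Compound 3 `C[C@]1(O)C[C@](c2ccnc(C(F)(F)F)c2)([C@H](O)c2ccccn2)C1` gives 500 nM, the lowest of the three numbers; the gap to compound 1 and the gap to compound 2 both lie beyond the scatter, so compound 3 stands as the strongest inhibitor of the measured set. For the measured compounds named here, no two measured compounds differ in only one place, so no single step has been measured.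

Compound 4 `O[C@H](c1ccccn1)[C@]1(c2ccnc(C(F)(F)F)c2)C[C@H](O)C1` is the next compound, not yet measured in this assay. It differs from compound 3 in one place: hydrogen in place of methyl on a saturated ring carbon. Compound 2 also lacks a methyl on its four-membered ring and gives a higher number than compound 3, but it differs from compound 3 in a second place as well, so it does not fix the size of this step. With nothing measured across this change, the expectation is a modest step toward a higher number, likely within the scatter. The expected step from compound 3 to compound 4 is a 1.8-fold higher number from compound 3 to compound 4 (0.26 log units; within the scatter). Compound 4 is estimated at 900 nM, with a range from 300 nM to 2500 nM.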

Compound 4, antagonist equilibrium constant: 60 nM
Estimate against measurement, compound 4: 15-fold (1.18 log units) above; the measured number lies below the stated range.
By their numbers in this assay, from the lowest: compound 4; then compound 3; then compounds 1 and 2 (each within the scatter of the next).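

In this assay, for the compounds shown here, the step of an 8.3-fold lower number from compound 3 to compound 4 (0.92 log units; beyond the scatter) is the only single change that can be read, and it lies beyond the scatter. It shows that this position is sensitive: on a saturated ring carbon of the four-membered ring, two ring bonds from the ring atom that bears the hydroxy(pyridin-2-yl)methyl group, hydrogen gives the lower number, so the methyl is not required for inhibition in this pair. The change removes just one carbon heavy atom, with no hydrogen-bond donor, hydrogen-bond acceptor or net charge counted as leaving, and nothing measured here explains why a change this small moves the number this far.

Going by these compounds, whether hydrogen in place of methyl gives a step of similar size with the other aryl groups remains open, as this result rests on one pair. Also open, on these data alone, is how an ethyl group, a fluorine atom or an amine would compare with hydrogen and methyl on this ring carbon.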